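The source may hold more compounds than are shown below. What is called first, only, known or untested is meant among the compounds shown, and "the series" means these compounds.

Measured compounds:
compound 1, `CCC(C(=O)N1CCN(c2ccc(Cl)cc2)CC1)N1C(=O)CCC1=O`, 25%
compound 2, `CC(C(=O)N1CCN(c2ccc(Cl)cc2)CC1)N1C(=O)CCC1=O`, 0%

Among the measured compounds shown here, in a functional assay on the whole organism (strain Swiss) with Mus musculus as the target, in the maximal electroshock model, with a stated time of 2 h, at a dose of 300 mg/kg by the intraperitoneal route (a lower number here means a weaker effect, a higher number a stronger effect of the compound at the dose given), compound 1 gives 25%, the higher of the two numbers measured so far. Compound 2, which carries `CC(C(=O)N1CCN(c2ccc(Cl)cc2)CC1)N1C(=O)CCC1=O`, gives 0% in this assay. For the measured compounds named here, the one measured step, a number 25 percentage points lower from compound 1 to compound 2 (beyond the scatter), concerns hydrogen in place of methyl on a saturated chain carbon and says nothing about the aromatic ring.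

Compound 3, `CCC(C(=O)N1CCN(c2ccc(F)cc2)CC1)N1C(=O)CCC1=O`, has not yet been measured. It differs from compound 1 by fluoro in place of chloro on an aromatic carbon. Going by the values given here, no measured pair changes the substituent on the aromatic ring, so the step from compound 1 to compound 2 does not bear on this change, and no size or direction can be drawn from it. Compound 3 is therefore expected to stay close to compound 1, with a step of a number 3 percentage points lower from compound 1 to compound 3 (within the scatter), not beyond the scatter in either direction. For compound 3 the estimate in this assay is 22%, within a range from 0% to 50%.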

Compound 3, a percentage reported as activity, at one dose (the size of the read-out at that dose, not a potency): 0%
Beside the measured number, compound 3's estimate is 22 percentage points above it, and the stated range covers the measured number.
By their numbers in this assay, from the lowest: compounds 2 and 3 (each within the scatter of the next); then compound 1.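

In this assay the substituent on the aromatic ring proves to matter: with fluoro in place of chloro on an aromatic carbon, para to a large group, the result is a number 25 percentage points lower from compound 1 to compound 3 (beyond the scatter) and the rest of the core of compound 1 stays unchanged. Among the compounds shown here, the earlier pair spoke only to the saturated chain carbon, so this is the first sign that the read-out also responds to the change from 4-chlorophenyl to 4-fluorophenyl. The exchange swaps one heavy atom for one heavy atom, with no ring, hydrogen-bond donor, hydrogen-bond acceptor or net charge entering or leaving, yet nothing at hand accounts for the drop.

The compounds shown leave open whether chloro is special at this place or whether bromo, methyl, trifluoromethyl or plain hydrogen on the same aromatic carbon would keep or raise the effect seen for compound 1. They also leave open how a longer chain on the saturated chain carbon would behave, and whether it would act the same way with fluoro as with chloro on the ring.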